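A few compounds are considered here, and "the series" means these few. Any claim that something is new, unique, unknown or untested is made for them only; others in the source may bear on it.

Measured compounds:

Compound 1, `CCCC(C(=O)NC(N)=O)C(C)C`, in a functional assay on the whole organism (strain Sprague-Dawley) with Rattus norvegicus as the target (a lower number here means that less compound is needed, a higher number that more compound is needed for the effect), compound 1 gives 45 mg/kg.
Compound 2, `CCCC(C(N)=O)C(C)C`, in this assay compound 2 gives 27 mg/kg.
Compound 3, `CC(C)C(C(N)=O)C(C)C`, in this assay compound 3 gives 60 mg/kg.

Compound 1 and compound 2 differ by hydrogen in place of carbamoyl on an amide-type nitrogen, and the step is a 1.7-fold lower number from compound 1 to compound 2 (0.22 log units; within the scatter), so the two numbers cannot be told apart. Compound 3 and compound 2 differ by propyl in place of isopropyl on a saturated chain carbon bound to a carbonyl carbon and a saturated chain carbon, and here the step is a 2.2-fold lower number from compound 3 to compound 2 (0.35 log units; beyond the scatter). How compound 1 and compound 3 differ as cores is not broken down here.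

Compound 4, `CCCC(CCC)C(=O)NC(N)=O`, is not yet measured. It differs from compound 1 by propyl in place of isopropyl on a saturated chain carbon bound to a carbonyl carbon and a saturated chain carbon, which is the same change as that from compound 3 to compound 2, at the same place word for word. An expected step of a 2.0-fold lower number from compound 1 to compound 4 (0.31 log units; beyond the scatter) is set beside the measured 2.2-fold lower number from compound 3 to compound 2 (0.35 log units; beyond the scatter), resting on that single earlier step together with the value of compound 1, 45 mg/kg. For compound 4 the expected value in this assay is therefore 22 mg/kg, estimated to lie between 12 mg/kg and 40 mg/kg.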

Compound 4, dose for half-maximal effect in the Rattus norvegicus assay: 77 mg/kg
Beside the measured number, compound 4's estimate is 3.5-fold (0.54 log units) below it; measured number outside the range, above it.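

In the Rattus norvegicus assay compound 1 gives 45 mg/kg and compound 4 gives 77 mg/kg; propyl in place of isopropyl on the core of compound 1 gives a 1.7-fold higher number from compound 1 to compound 4 (0.23 log units; within the scatter), so those two numbers cannot be told apart, and the change does not repeat the step seen on the core of compound 3: the same change on two cores in the Rattus norvegicus assay, a 2.2-fold lower number (0.35 log units; beyond the scatter) from compound 3 to compound 2 and a 1.7-fold higher number (0.23 log units; within the scatter) from compound 1 to compound 4, 3.8-fold (0.58 log units) apart, beyond the scatter of two such steps. In this series, then, the earlier step could not be carried over from one core to the other as it stood. Among the compounds shown here, this does not show why the two steps part, and with only one step on each core it gives no rule for how the change would behave on any further core.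

On these data alone, in a physicochemical assay for solubility (on this read-out lower numbers stand for lower solubility and higher numbers for higher solubility), compound 1 gives 130 ug/mL and compound 4 gives 120 ug/mL; the same change gives a 1.1-fold lower number from compound 1 to compound 4 (0.03 log units; within the scatter), and whether that holds on the core of compound 3 remains open. Also open, as far as these compounds go, is how a longer chain such as butyl in that place, or a carboxylic acid in place of the carbamoyl, would behave on either core.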